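The compounds below may be only part of what the source reports. "The series", "measured", "known", "first", "only" and "open" are said of these compounds alone.

Compound 1 `Cc1nc2c(OCc3ccccc3)cccn2c1C(N)=O` gave 42% in a functional assay on the whole organism with Rattus norvegicus as the target, with a stated time of 4 h, at a dose of 40 mg/kg by the intraperitoneal route; a lower number here means less inhibition, a higher number more inhibition at the dose given (going by the name of the read-out). Compound 2 `Cc1nc2c(OCc3ccccc3)cccn2c1CS(C)(=O)=O` gave 61% in this assay.

Compound 2 stands highest of the two numbers measured, and the step of a number 19 percentage points higher from compound 1 to compound 2 (beyond the scatter) lies beyond the scatter. Compound 3 `Cc1nc2c(OCc3ccccc3)cccn2c1C` differs from compound 2 by hydrogen in place of methylsulfonyl on a saturated chain carbon bound to an aromatic carbon. Within the data shown here, no measured step removes this group, so only the step of a number 19 percentage points higher from compound 1 to compound 2 (beyond the scatter) bears on it, showing that what sits on this aromatic carbon moves the number modestly. Taking the methylsulfonyl away is expected to lower the number, with a step of about a number 21 percentage points lower from compound 2 to compound 3 (beyond the scatter). Compound 3 is estimated at 40%, in a range of 20% to 60%.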

Compound 3, a percentage reported as inhibition, in the whole organism at one dose (the size of the read-out at that dose, not a potency): 99%
The estimate for compound 3 lay 59 percentage points below the measured number; measured number outside the range, above it.
By their numbers in this assay, from the lowest: compound 1; then compound 2; then compound 3.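

At this aromatic carbon, the methylsulfonyl proves unnecessary for the read-out in this assay: replacing it with hydrogen gives a number 38 percentage points higher from compound 2 to compound 3 (beyond the scatter) and the plain methyl also outdoes the carbamoyl, with a number 57 percentage points higher from compound 1 to compound 3 (beyond the scatter) in this comparison. Of the three groups shown here, the unadorned methyl gives the highest number, so neither polar-looking substituent tried so far is required. Nothing available explains this rise. From the compounds shown here alone, it remains open whether hydrogen directly on this aromatic carbon, an ethyl chain or an amine would hold the number. A single dose also leaves open how the compounds compare at other doses.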